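Cyano replaced on the aryl of compound 2

A few compounds are considered here, and "the series" means these few. Any claim that something is new, unique, unknown or untested is made for them only; others in the source may bear on it.

Compound 2, `COc1ccc([C@H]2CC(=O)N(c3ccc(C#N)cc3)C2)cc1OC1CCCC1`, is the starting point of this step. In a functional assay on HEK293 cells (Homo sapiens) for cytotoxicity (on this read-out higher numbers stand for lower toxicity in this test and lower numbers for higher toxicity in this test), compound 2 gives > 10000 nM, which is a limit of the test and not a number. Going by the values given here, compound 1, `COc1ccc([C@H]2CC(=O)N(c3cc(N)cc(N)c3)C2)cc1OC1CCCC1`, is the only other measured member. In this assay compound 1 gives > 10000 nM, again a limit. Among the compounds with values here, the one measured step, a step that the two limits leave unreadable from compound 1 to compound 2, cannot be read because of the limit of > 10000 nM in this assay, at which 2 of the 2 values shown sit. Compound 3, `COc1ccc([C@H]2CC(=O)N(c3ccc([S+](C)[O-])cc3)C2)cc1OC1CCCC1`, differs from compound 2 by a group of 3 heavy atoms (1 carbon, 1 oxygen, 1 sulfur; no ring) in place of a group of 2 heavy atoms (1 carbon, 1 nitrogen; no ring), on an aromatic carbon. Within the data shown here, no measured step bears on this change, so no shift beyond the scatter is expected. Compound 3 is expected to give 12000 nM, between 5000 nM and 30000 nM, the expected step being a step that the limit leaves unreadable from compound 2 to compound 3.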

Compound 3, half-maximal cytotoxic concentration: 7510 nM
Compound 3: the middle estimate sits 1.6-fold (0.20 log units) above what was measured; low and high end bracket the measured number.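

In this assay, this aromatic carbon para to a large group now carries a change that yields a number and not a limit: compound 3 gives 7510 nM. The group of 3 heavy atoms in place of cyano gives an at least 1.3-fold lower number from compound 2 to compound 3 (0.12 log units; that floor lies within the scatter), and the full aryl change on the amide-type nitrogen gives an at least 1.3-fold lower number from compound 1 to compound 3 (0.12 log units; that floor lies within the scatter). The true size of both steps cannot be read because the other two compounds give only a limit: the limit of > 10000 nM in this assay, at which 2 of the 3 values shown sit.

As far as these compounds go, an amine or a carboxylic acid on this same aromatic carbon remains open. So does whether any group here gives a step clearly beyond the scatter.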